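This account rests on a few compounds, and the source may have more. Where it says the series, first, only, none or still open, it means among the compounds named here.

In a functional assay on Jurkat cells (Homo sapiens) (on this read-out lower numbers stand for stronger inhibition and higher numbers for weaker inhibition), compound 1 `CC(C)[C@H](NC(=O)COc1cccc2ccccc12)C(=O)N[C@@H](CC(=O)O)C(=O)COc1ccccc1` gives 14000 nM. Compound 2 `CC(C)[C@H](NC(=O)COc1cccc2ccccc12)C(=O)N[C@@H](CC(=O)O)C(=O)COc1cccc(C(F)(F)F)c1` reaches only the limit of this assay, > 100000 nM. Compound 3 `CC(C)[C@H](NC(=O)COc1cccc2ccccc12)C(=O)N[C@@H](CC(=O)O)C(=O)COc1ccc([N+](=O)[O-])cc1` likewise reaches only the limit, > 100000 nM. Each of these two differs from compound 1 by a substituent on an aromatic carbon, and both steps, an at least 7.1-fold higher number from compound 1 to compound 2 (0.85 log units; beyond the scatter) and an at least 7.1-fold higher number from compound 1 to compound 3 (0.85 log units; beyond the scatter), run the same way, while the step that the two limits leave unreadable from compound 2 to compound 3 cannot be read because of the limit of > 100000 nM in this assay, at which 2 of the 3 values shown sit. Compound 4 `CC(C)[C@H](NC(=O)COc1cccc2ccccc12)C(=O)N[C@@H](CC(=O)O)C(=O)COc1cc(F)c(F)cc1F` carries the change (2,4,5-trifluorophenyl in place of 3-(trifluoromethyl)phenyl on an oxygen on a saturated carbon), again a substituted ring where the two substituted rings gave only limits. Compound 4 is therefore expected to stay near that limit, with the step of an at least 1.6-fold lower number from compound 2 to compound 4 (0.22 log units; that floor lies within the scatter) expected to be small. For compound 4 the estimate is 60000 nM, between 15000 nM and 200000 nM.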

Compound 4, half-maximal inhibitory concentration: 39300 nM
For compound 4 the middle estimate is 1.5-fold (0.18 log units) above the measured one; the range from low to high includes it.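

In this assay, a substituted ring on this oxygen need not end at the limit: 2,4,5-trifluorophenyl gives a readable value, with an at least 2.5-fold lower number from compound 2 to compound 4 (0.40 log units; beyond the scatter) and an at least 2.5-fold lower number from compound 3 to compound 4 (0.40 log units; beyond the scatter). Both of these steps are floors and not full sizes: the limit of > 100000 nM in this assay, at which 2 of the 4 values shown sit. Plain phenyl still keeps the lower number, with a 2.8-fold higher number from compound 1 to compound 4 (0.45 log units; beyond the scatter), so none of the three substituted rings shown improves on it.

The compounds shown leave open whether the number of fluorines or their arrangement on the ring sets this difference. They also leave open whether a single fluorine, a methoxy group or a carboxylic acid on the phenyl ring would match or pass compound 1.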